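This account rests on a few compounds, and the source may have more. Where it says the series, first, only, none or still open, it means among the compounds named here.

Measured compounds:
- compound 1, `COc1cc(/C=C/C(C)=O)ccc1OCc1cn(-c2ccnc3cc(Cl)ccc23)nn1`: 3.5
- compound 2, `COc1ccc(C(=O)/C=C/c2ccc(OCc3cn(-c4ccnc5cc(Cl)ccc45)nn3)c(OC)c2)c(OC)c1`: 4.3
- compound 3, `COc1ccc(C(=O)/C=C/c2ccc(O)c(CN3CCN(c4ccnc5cc(Cl)ccc45)CC3)c2)c(OC)c1`: 2

In a physicochemical assay for lipophilicity, read by HPLC, at pH 3 (on this read-out higher numbers stand for higher lipophilicity and lower numbers for lower lipophilicity), compound 3 gives 2, the lowest of the three numbers. Its nearest neighbour is compound 1 at 3.5, and compound 2 lies furthest away at 4.3; both gaps are beyond the scatter.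

Compound 4, `COc1ccc(C(=O)/C=C/c2cc(CN3CCN(c4ccnc5cc(Cl)ccc45)CC3)c(O)c(OC)c2)c(OC)c1`, has not yet been measured in this assay. It differs from compound 3 in a single place: methoxy in place of hydrogen on an aromatic carbon. The new group sits on an aromatic carbon of a six-membered aromatic ring of carbon only, ortho to a hydroxy group and meta to two large groups.

Within the data shown here, only one measured step exists, a number 0.80 log units higher from compound 1 to compound 2 (beyond the scatter). That step adds a whole aromatic ring carrying two methoxy groups and so does not match a lone methoxy entering in place of hydrogen; it bears on the present step only loosely, as an upper bound on what methoxy-bearing additions have done here. A single methoxy without a new ring is expected to move this assay by much less, and in the upward direction if at all.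

For compound 4 the step is estimated at a number 0.20 log units higher from compound 3 to compound 4 (within the scatter), a change that may fall within the scatter. Compound 4 is therefore expected to give about 2.2, within a range from 1.8 to 2.6.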

Compound 4, distribution coefficient: 2.1
For compound 4 the middle estimate is 0.10 log units above the measured one; the range from low to high includes it.
By their numbers in this assay, from the lowest: compounds 3 and 4 (each within the scatter of the next); then compound 1; then compound 2.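

In this assay, methoxy in place of hydrogen on an aromatic carbon, ortho to a hydroxy group and meta to two large groups, gives a number 0.10 log units higher from compound 3 to compound 4 (within the scatter), so at this position the two compounds cannot be told apart on this read-out. Among these compounds, the only earlier step, a number 0.80 log units higher from compound 1 to compound 2 (beyond the scatter), put 2,4-dimethoxyphenyl in place of methyl on a carbonyl carbon, and so it said nothing about this aromatic carbon or about a lone methoxy entering without a new ring. No measurement offered here accounts for this result.

Going by these compounds, whether an amine, a carboxylic acid or a longer chain such as ethoxy on this same aromatic carbon would also stay within the scatter of compound 3 remains open. On these data alone, it is also open whether methoxy at this place would read the same way on the core of compound 2, or in the absence of the neighbouring hydroxy group's partner compounds at a different pH.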